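This account rests on a few compounds, and the source may have more. Where it says the series, first, only, none or still open, it means among the compounds named here.

Working notes on the series. Three compounds sharing the same core, each bearing a five-membered aromatic ring on the saturated chain carbon bound to the amine nitrogen, have been run in an ADME assay on MDCK cells (Canis lupus familiaris) for cytotoxicity, read by microscopy, with a stated time of 48 h; on this read-out higher numbers stand for lower toxicity in this test and lower numbers for higher toxicity in this test. Compound 1 `C[C@H]1[C@H](NCc2cc(Br)cs2)C[C@H]2C[C@@H]1C2(C)C` gives 6250 nM and stands second highest of the three numbers, nearest compound 2 and furthest from compound 3. Compound 2 `C[C@H]1[C@H](NCc2cc(-c3ccccc3)cs2)C[C@H]2C[C@@H]1C2(C)C` gives 5000 nM, and compound 3 `C[C@H]1[C@H](NCc2cc(-c3ccsc3)cs2)C[C@H]2C[C@@H]1C2(C)C` gives 25000 nM. Compound 4 `Cc1csc(CN[C@@H]2C[C@H]3C[C@@H]([C@H]2C)C3(C)C)n1` is not yet measured; relative to compound 1 the change is 4-methyl-1,3-thiazol-2-yl in place of 4-bromothiophen-2-yl on a saturated chain carbon bound to an amine nitrogen, so the ring itself is exchanged rather than the group on an aromatic carbon. The measured steps of a 1.3-fold lower number from compound 1 to compound 2 (0.10 log units; within the scatter), a 4.0-fold higher number from compound 1 to compound 3 (0.60 log units; beyond the scatter) and a 5.0-fold higher number from compound 2 to compound 3 (0.70 log units; beyond the scatter) all vary only the group on an aromatic carbon of the five-membered ring, and none swaps the ring, so they bear on the present step only loosely: one was within the scatter and two were modest rises. A step within the scatter, of no settled direction, is therefore expected for compound 4 in this assay. Compound 4 is estimated at 6250 nM, with a range from 2500 nM to 20000 nM, which is expected to mean no change at the digits printed from compound 1 to compound 4 (within the scatter).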

Compound 4, minimum cytotoxic concentration: > 100000 nM
Compound 4: only a limit was reported (the forecaster's own chance of this, stated with the estimate: 15%); at least 16-fold (1.20 log units) between middle value and limit.
By their numbers in this assay, from the lowest: compounds 2 and 1 (each within the scatter of the next); then compound 3. At a limit, above all of these: compound 4.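

In this assay compound 4 is reported only as a limit, not as a number: the limit of > 100000 nM in this assay, at which 1 of the 4 values shown sits.

Going by these compounds alone, exchanging the ring on the saturated chain carbon bound to an amine nitrogen gives an at least 16-fold higher number from compound 1 to compound 4 (1.20 log units; beyond the scatter), the only large step, whereas the earlier changes to the group on an aromatic carbon stayed within the scatter or were modest. This step exchanges 4-bromothiophen-2-yl for 4-methyl-1,3-thiazol-2-yl, so the ring and its group change together and neither can be credited alone.

From the compounds shown here alone, whether the step follows the added ring nitrogen or the methyl in place of bromo remains open; a 4-methylthiophen-2-yl or a 4-bromo-1,3-thiazol-2-yl group at this place would separate the two. Going by these compounds, how far the true value of compound 4 lies past its limit also remains open.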